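A few compounds are considered here, and "the series" means these few. Any claim that something is new, unique, unknown or untested is made for them only; others in the source may bear on it.

Working notes on the series. Compound 1 `CN1CCN(CCCS(=O)(=O)c2ccc3nc(NC(=O)NC(=O)c4cc(-n5cccc5)ccc4Cl)sc3c2)CC1` and compound 2 `CN1CCN(CCCS(=O)(=O)c2ccc3nc(NC(=O)NC(=O)c4cc(-n5cccn5)c(Cl)cc4Cl)sc3c2)CC1` share a core and have been measured in a physicochemical assay for lipophilicity; a higher number here means a more lipophilic compound, a lower number a more polar compound. Compound 1 gives 2.6 in this assay, and compound 2 gives 2.3; the two numbers lie within the usual scatter of each other, so no order between them can be read from the data. Compound 1 is nonetheless the reference point for the next compound, as its number is the one on record that sits closest in structure to what follows.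

Compound 3 `CN1CCN(CCCS(=O)(=O)c2ccc3nc(NC(=O)NC(=O)c4cc(N5CCCC5)ccc4Cl)sc3c2)CC1` has not yet been measured in this assay. Compared with compound 1 it differs in one place: pyrrolidin-1-yl in place of 1H-pyrrol-1-yl on an aromatic carbon. Among the measured compounds shown here, no step between measured compounds of this kind is on record, so the expectation rests only on the two numbers above and on the change itself, which keeps the ring size and the count of donors and acceptors unchanged. The step from compound 1 to compound 3 in this assay is therefore expected to be small, a number 0.10 log units lower from compound 1 to compound 3 (within the scatter), and not clearly beyond the scatter in either direction. For compound 3 the value in this assay is estimated at 2.5, with a range from 2 to 3.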

Compound 3, distribution coefficient: 3.1
The estimate for compound 3 lay 0.60 log units below the measured number; the measured number lies above the stated range.
By their numbers in this assay, from the lowest: compounds 2 and 1 (each within the scatter of the next); then compound 3.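

In this assay, among the compounds shown here, replacing 1H-pyrrol-1-yl with pyrrolidin-1-yl on an aromatic carbon, para to a chloro group and meta to a large group, gives a number 0.50 log units higher from compound 1 to compound 3 (beyond the scatter), the first step on record at this position and the first that can be read beyond the scatter. The two groups match in heavy atoms, ring size, hydrogen-bond donors, hydrogen-bond acceptors and net charge, and differ in that one five-membered ring is aromatic and the other non-aromatic, so the number at this position can move with those counts unchanged. Nothing on record explains the size or direction of this step.

A single pair cannot show whether the same step would appear with a different substitution pattern on the ring or elsewhere on the shared core. Going by these compounds, it also remains open whether a six-membered piperidine ring, a morpholine ring or an open-chain diethylamino group at this place would give a number closer to compound 3 or to compound 1.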